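The source may hold more compounds than are shown below. What is called first, only, known or untested is meant among the compounds shown, and "the series" means these compounds.

Working notes on the series.

Compound 1 `ClCc1cccc(Cn2cnc3c(Cl)ncnc32)c1` gives 6310 nM in a functional assay on SK-MEL-5 cells (Homo sapiens) for cytotoxicity, read by sulforhodamine B assay, with a stated time of 48 h; a lower number here means a stronger inhibitor of growth, a higher number a weaker inhibitor of growth. Compound 2 `ClCc1cccc(Cn2cnc3c(Cl)nc(Cl)nc32)c1` carries the change chloro in place of hydrogen on an aromatic carbon and gives 3020 nM; the resulting step is a 2.1-fold lower number from compound 1 to compound 2 (0.32 log units; beyond the scatter). Compound 3 `ClCc1ccccc1Cn1cnc2ncnc(Cl)c21` is built on a differently joined core of the same atoms as compound 1; the difference between the two cores is not broken down here. In this assay compound 3 gives 4070 nM, which sits within the scatter of both compound 2 and compound 1, so no order between these three can be read from the numbers.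

Compound 4 `ClCc1ccccc1Cn1cnc2nc(Cl)nc(Cl)c21` has not yet been measured. It differs from compound 3 by chloro in place of hydrogen on an aromatic carbon, which is the same change as that from compound 1 to compound 2, at a place described in identical terms. On that single measured precedent, the step of a 2.1-fold lower number from compound 1 to compound 2 (0.32 log units; beyond the scatter), compound 4 is expected to show a step of about a 2.0-fold lower number from compound 3 to compound 4 (0.31 log units; beyond the scatter), with a wide band because one pair of compounds supports the expectation. The estimated value for compound 4 in this assay is 2000 nM, with a likely range from 900 nM to 4500 nM.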

Compound 4, concentration for total growth inhibition: 2180 nM
The estimate for compound 4 lay 1.1-fold (0.04 log units) below the measured number; measured number inside the range.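

In this assay, chloro in place of hydrogen on an aromatic carbon gives a 1.9-fold lower number from compound 3 to compound 4 (0.27 log units; within the scatter), so this step taken alone cannot be told apart from repeat variation. Set beside the earlier step, the change looks the same on the two cores: the same change on two cores in this assay, a 2.1-fold lower number (0.32 log units; beyond the scatter) from compound 1 to compound 2 and a 1.9-fold lower number (0.27 log units; within the scatter) from compound 3 to compound 4, 1.1-fold (0.05 log units) apart, within the scatter of two such steps. This supports carrying the size of the step from one of these cores to the other in this assay, but it rests on two pairs of compounds and shows neither that the step would hold on any further core nor why it takes this size.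

The compounds shown leave open whether an amine or a methoxy group on the same aromatic carbon, between the two ring nitrogen atoms, would give a step of similar size. They also leave open whether the chloro step would persist if the chloromethyl group gave way to a hydroxymethyl group or a longer chain.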